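Swapping One Amine Ring for Another: Cytotoxicity Outlook

This account rests on a few compounds, and the source may have more. Where it says the series, first, only, none or still open, it means among the compounds named here.

Compound 1 `CN1CCN(CC(=O)Nc2ccc(-c3nc4cc(Cl)c(Cl)cc4[nH]3)cc2)CC1`: 11000 nM
Compound 2 `Oc1ccc(-c2nc3cc(Cl)c(Cl)cc3[nH]2)cc1`: 12000 nM
Compound 3 `CCC(=O)Nc1ccc(-c2nc3cc(C(F)(F)F)ccc3[nH]2)cc1`: >= 100000 nM, a limit of the assay rather than a number

In an ADME assay on MT4 cells (Homo sapiens) for cytotoxicity, read by MTT assay, with a stated time of 96 h (a lower number here means that less compound is tolerated, a higher number that more compound is tolerated), compound 1 gives 11000 nM, the lower of the two numbers present. Compound 2 gives 12000 nM, which sits within the scatter of that figure, so the two cannot be ranked. Compound 3 reaches only the limit (the limit of >= 100000 nM in this assay, at which 1 of the 3 values shown sits).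

Compound 4 `O=C(CN1CCCC1)Nc1ccc(-c2nc3cc(Cl)c(Cl)cc3[nH]2)cc1` differs from compound 1 in one place: pyrrolidin-1-yl in place of 4-methylpiperazin-1-yl on a saturated chain carbon bound to a carbonyl carbon. Going by the values given here, no measured pair shows this change, so the expectation rests on compound 1 alone. The step from compound 1 to compound 4 is expected to be small, no larger than the scatter: a 1.2-fold lower number from compound 1 to compound 4 (0.09 log units; within the scatter). Compound 4 is therefore estimated at 9000 nM, within 4000 nM to 25000 nM.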

Compound 4, half-maximal cytotoxic concentration: 8000 nM
Compound 4: the middle estimate sits 1.1-fold (0.05 log units) above what was measured; the measured number falls inside the stated range.
By their numbers in this assay, from the lowest: compounds 4, 1 and 2 (each within the scatter of the next). At a limit, above all of these: compound 3.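

In this assay, the swap of 4-methylpiperazin-1-yl for pyrrolidin-1-yl on a saturated chain carbon bound to a carbonyl carbon gives a 1.4-fold lower number from compound 1 to compound 4 (0.14 log units; within the scatter), so compound 1 and compound 4 cannot be ranked. For this pair, then, going from a six-membered ring with 2 hetero atoms to a five-membered ring with 1 produces no readable shift in cytotoxicity. Nothing measured here offers a reason for this.

Going by these compounds, whether a morpholine ring, an open-chain dimethylamino group or a carboxylic acid at this place would leave the number similarly unmoved remains open.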